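Microsomal stability in a fused bicyclic series: compound 4

The compounds below may be only part of what the source reports. "The series", "measured", "known", "first", "only" and "open" are said of these compounds alone.

In an ADME assay on microsomes from liver (Mus musculus) for metabolic stability, read by LC-MS, with a stated time of 30 min, tested at 0.1 uM (on this read-out higher numbers stand for a more stable compound and lower numbers for a less stable compound), compound 1 `COc1ccc(Nc2cc3[nH]c(-c4cccc(C(F)(F)F)c4)nc3cn2)nc1` gives 33% and compound 3 `CN1CCN(c2ccc(Nc3cc4[nH]c(-c5cccc(C(F)(F)F)c5)nc4cn3)nc2)CC1` gives 35%; the step of a number 2 percentage points higher from compound 1 to compound 3 (within the scatter) lies within the scatter. Compound 2 `FC(F)(F)c1ccc(Nc2cc3[nH]c(-c4cccc(C(F)(F)F)c4)nc3cn2)nc1` gives 91%, the highest of the three, with a number 58 percentage points higher from compound 1 to compound 2 (beyond the scatter) and, going the other way, a number 56 percentage points lower from compound 2 to compound 3 (beyond the scatter). Compound 4 `FC1(F)CC(c2nc3cnc(Nc4ccc(C(F)(F)F)cn4)cc3[nH]2)C1` differs from compound 2 by 3,3-difluorocyclobutyl in place of 3-(trifluoromethyl)phenyl on an aromatic carbon. For the measured compounds named here, no measured step touches that place; all three concern a substituent elsewhere, on an aromatic carbon, so they offer no direct guide. The trifluoromethyl group that compound 2 carries is retained. A modest downward step is expected; for compound 4 the expected step is a number 21 percentage points lower from compound 2 to compound 4 (beyond the scatter). Compound 4 is estimated at 70%, with a range of 40% to 92%.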

Compound 4, percent of the compound remaining in the Mus musculus assay: 75%
Estimate against measurement, compound 4: 5 percentage points below, within the range that was stated.
By their numbers in the Mus musculus assay, from the lowest: compounds 1 and 3 (each within the scatter of the next); then compound 4; then compound 2.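

In the Mus musculus assay the only step shown at this place, on an aromatic carbon of a five-membered aromatic ring with 2 nitrogen, is a number 16 percentage points lower from compound 2 to compound 4 (beyond the scatter), so a four-membered non-aromatic ring can stand in for the six-membered aromatic ring at a modest cost. In a physicochemical assay for solubility, using the shake flask method, in simulated intestinal fluid, measured as kinetic solubility, with a stated time of 20 h, at pH 6.5 (on this read-out higher numbers stand for higher solubility and lower numbers for lower solubility), compound 4 gives 161000 nM. In the physicochemical assay compound 2 gives >= 50000 nM, a limit of the assay and not a number, so the step to compound 4 cannot be read: the limit of >= 50000 nM in the physicochemical assay, at which 1 of the 2 values shown sits.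

Still open, from the compounds shown here alone, is how an amine or a carboxylic acid would read at this place. Also open, going by these compounds, is whether the step holds with methoxy or 4-methylpiperazin-1-yl in place of the trifluoromethyl group that compounds 2 and 4 share.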